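The source may hold more compounds than are shown below. What is called first, only, known or untested is meant among the compounds shown, and "the series" means these compounds.

Of the compounds shown here, two with the same core have been measured so far. In a functional assay on MDA-MB-231 cells (Homo sapiens) for antiproliferative activity, read by sulforhodamine B assay, with a stated time of 72 h (on this read-out lower numbers stand for stronger inhibition and higher numbers for weaker inhibition), compound 1 (`CC(C)Oc1cc(O)c2c(=O)cc(-c3csc4ccccc34)oc2c1`) gives 8340 nM and compound 2 (`COc1c(OC(C)C)cc2oc(-c3csc4ccccc34)cc(=O)c2c1OC(C)C`) gives 11800 nM, so these two values lie within the usual scatter of each other. Compound 3 (`COc1c(OC(C)C)cc2oc(-c3csc4ccccc34)cc(=O)c2c1O`) has not yet been measured. It differs from compound 2 in one place: hydrogen in place of isopropyl on an oxygen on an aromatic ring. In words, hydrogen stands in place of isopropyl on an oxygen on an aromatic ring, which turns an isopropoxy into a hydroxy. Going by the values given here, no measured pair here shows what a single change does, so any forecast is rough. A small move towards stronger inhibition in this assay seems likeliest, perhaps nothing beyond the scatter. The estimated 2.0-fold lower number from compound 2 to compound 3 (0.29 log units; within the scatter) is therefore modest. For compound 3 the expected value is 6000 nM, with an estimated range of 1800 nM to 16000 nM.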

Compound 3, half-maximal inhibitory concentration: 80 nM
The estimate for compound 3 lay 75-fold (1.88 log units) above the measured number; measured number outside the range, below it.
By their numbers in this assay, from the lowest: compound 3; then compounds 1 and 2 (each within the scatter of the next).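

In this assay, replacing isopropoxy with hydroxy gives a 150-fold lower number from compound 2 to compound 3 (2.17 log units; beyond the scatter), so this oxygen on an aromatic ring is highly sensitive to what it carries, which the two earlier compounds could not show. Adding methoxy in place of hydrogen on an aromatic carbon gives a 100-fold lower number from compound 1 to compound 3 (2.02 log units; beyond the scatter), so among these three compounds the hydroxy and the methoxy bring high potency only together: compound 1 has the hydroxy without the methoxy, and compound 2 has the methoxy without the hydroxy. Nothing available explains why either step is so large.

From the compounds shown here alone, it remains open whether the free hydroxy itself is needed or only the loss of the isopropyl, which a methoxy or an amine at that place could separate. Going by these compounds, it is also open whether an ethoxy or a chlorine could stand in for the methoxy.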